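Hydroxyethyl in Place of Allyl on the Amide Nitrogen

This account rests on a few compounds, and the source may have more. Where it says the series, first, only, none or still open, it means among the compounds named here.

Compound 1 `C=CCN(C)C(=O)c1ccc(C(CC)(CC)c2ccc(OCCC(O)(CC)CC)c(C)c2)n1CC` carries an allyl(methyl)carbamoyl group on the shared core. In an assay on cells for agonist activity at vitamin D3 receptor (Homo sapiens), with a stated time of 96 h (on this read-out higher numbers stand for an effect only at larger amounts of compound and lower numbers for an effect already at smaller amounts), compound 1 gives > 10000 nM, which is a limit of the assay and not a number. Compound 2 `C#CC(C)OC(=O)c1ccc(C(CC)(CC)c2ccc(OCCC(O)(CC)CC)c(C)c2)n1CC` replaces that amide with an ester; in this assay compound 2 gives 2650 nM. Compound 3 `CCn1c(C(=O)Nc2ccc(OC(F)(F)F)cc2)ccc1C(CC)(CC)c1ccc(OCCC(O)(CC)CC)c(C)c1` gives > 10000 nM in this assay, again a limit of the assay. The measured steps read an at least 3.7-fold lower number from compound 1 to compound 2 (0.57 log units; beyond the scatter) and an at least 3.7-fold higher number from compound 2 to compound 3 (0.57 log units; beyond the scatter), while a step that the two limits leave unreadable from compound 1 to compound 3. Compound 1 thus stands at the weak end of what is shown, on (the limit of > 10000 nM in this assay, at which 2 of the 3 values shown sit).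

Compound 4 `CCn1c(C(=O)N(C)CCO)ccc1C(CC)(CC)c1ccc(OCCC(O)(CC)CC)c(C)c1` differs from compound 1 by hydroxymethyl in place of vinyl on a saturated chain carbon bound to an amide-type nitrogen. Going by the values given here, none of the measured steps touches the allyl chain; each exchanges the whole group on the carbonyl carbon, so they bear on the present step only indirectly, and none of them shows a gain that starts from an amide. Compound 4 is therefore expected to remain near the limit, because compound 1 already sits on (the limit of > 10000 nM in this assay, at which 2 of the 3 values shown sit). The step that the limit leaves unreadable from compound 1 to compound 4 is expected to show no change beyond the scatter. Compound 4 is estimated at 15000 nM, with a range from 4000 nM to 60000 nM.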

Compound 4, half-maximal effective concentration: 52.7 nM
Compound 4: the middle estimate sits 280-fold (2.45 log units) above what was measured; measured number outside the range, below it.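

The earlier compounds shown here showed a gain only with an ester on the carbonyl carbon, whereas here a change within the amide itself carries one: in this assay, hydroxymethyl in place of vinyl on a saturated chain carbon bound to an amide-type nitrogen gives an at least 180-fold lower number from compound 1 to compound 4 (2.27 log units; beyond the scatter). The (2-hydroxyethyl)(methyl)amino group also separates clearly from the two other groups on the carbonyl carbon, with an at least 180-fold lower number from compound 3 to compound 4 (2.27 log units; beyond the scatter) and a 50-fold lower number from compound 2 to compound 4 (1.70 log units; beyond the scatter), so among the compounds shown the ester of compound 2 no longer gives the lowest number. Compound 1 and compound 3 each rest on a limit of the assay and not on a number, so the first two of these steps give only a smallest size: the limit of > 10000 nM in this assay, at which 2 of the 4 values shown sit.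

As far as these compounds go, whether the gain belongs to the hydroxyl or to the loss of the double bond stays open, and a propyl or 2-methoxyethyl chain on the same nitrogen would separate the two. Equally open, from the compounds shown here alone, is how a 3-hydroxypropyl chain, or a carboxylic acid in place of the hydroxymethyl, would read in this assay.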